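Swapping a Fluorine for a Methyl on a Sulfonamide Pair

The compounds below may be only part of what the source reports. "The series", "measured", "known", "first", "only" and "open" are said of these compounds alone.

Measured so far:
Compound 1 `O=S(=O)(Nc1ccccc1NS(=O)(=O)c1ccc(F)cc1)c1ccc(F)cc1` — 28300 nM
Compound 2 `Cc1ccc(NS(=O)(=O)c2ccc(F)cc2)c(NS(=O)(=O)c2ccc(F)cc2)c1` — 16200 nM

Both compounds were tested in an assay for binding affinity to protein lin-28 homolog A (Mus musculus), with a stated time of 1 h; on this read-out lower numbers stand for stronger inhibition and higher numbers for weaker inhibition. Among the measured compounds shown here, compound 1 gives 28300 nM, and compound 2 gives 16200 nM, the lowest of the two numbers; the only step seen so far, a 1.7-fold lower number from compound 1 to compound 2 (0.24 log units; within the scatter), stays within the scatter, so the two compounds cannot be told apart on these numbers.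

Compound 3 `Cc1ccc(S(=O)(=O)Nc2ccc(C)cc2NS(=O)(=O)c2ccc(F)cc2)cc1` has not yet been measured. It differs from compound 2 in one place: methyl in place of fluoro on an aromatic carbon. For the measured compounds named here, no measured step touches the same position, and the one known step, a 1.7-fold lower number from compound 1 to compound 2 (0.24 log units; within the scatter), was within the scatter, so there is nothing in the data that points to a change beyond the scatter in this assay either.

The expectation for compound 3 is therefore an unchanged number, a 1.1-fold lower number from compound 2 to compound 3 (0.03 log units; within the scatter), with an estimate of 15000 nM and a range from 5000 nM to 45000 nM.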

Compound 3, half-maximal inhibitory concentration: 11700 nM
Beside the measured number, compound 3's estimate is 1.3-fold (0.11 log units) above it; the measured number falls inside the stated range.
By their numbers in this assay, from the lowest: compounds 3, 2 and 1 (each within the scatter of the next, the first and the last beyond it).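

In this assay the change from 4-fluorophenyl to 4-methylphenyl gives a 1.4-fold lower number from compound 2 to compound 3 (0.14 log units; within the scatter) and so stays within the scatter. Among the compounds shown here, this is the first look at this carbon, which the earlier step did not touch, and it shows that methyl can stand in place of fluoro here with no difference that these numbers can resolve. Nothing on hand offers an explanation for this result.

The compounds shown leave open whether a group of another kind on this carbon, such as an amine, a carboxylic acid or a longer chain, would move the number beyond the scatter. They also leave open whether the same swap on the 4-fluorophenyl group that remains in compound 3 would do so.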